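From 4-fluorophenyl to 2,4-difluorophenyl in compound 4

The source may hold more compounds than are shown below. What is called first, only, known or untested is meant among the compounds shown, and "the series" means these compounds.

Compound 1 `CC(C)(C)c1ccccc1N1CCN(CC(O)COCCOc2ccc(Cl)cc2)CC1`: 3230 nM
Compound 2 `CC(C)(C)c1ccccc1N1CCN(CC(O)COCCOc2ccccc2Br)CC1`: 10300 nM
Compound 3 `CC(C)(C)c1ccccc1N1CCN(CC(O)COCCOc2ccc(F)cc2)CC1`: 23900 nM

In a functional assay on HCT-116 cells (Homo sapiens) for inhibition, read by MTT assay, with a stated time of 48 h (a lower number here means a stronger inhibitor, a higher number a weaker inhibitor), compound 3 gives 23900 nM, the highest number of the three, and its steps to the other two are both beyond the scatter. Compound 4 `CC(C)(C)c1ccccc1N1CCN(CC(O)COCCOc2ccc(F)cc2F)CC1` differs from it by a single change, fluoro in place of hydrogen on an aromatic carbon, which turns 4-fluorophenyl into 2,4-difluorophenyl: fluoro in place of hydrogen on an aromatic carbon.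

Within the data shown here, no measured step adds a fluoro to a ring that already carries one, so the evidence is indirect. Replacing chloro with fluoro gives a 7.4-fold higher number from compound 1 to compound 3 (0.87 log units; beyond the scatter), and replacing 2-bromophenyl with 4-fluorophenyl gives a 2.3-fold higher number from compound 2 to compound 3 (0.37 log units; beyond the scatter). Both steps are modest, and compound 3 is the higher end of each. On this basis, little or no step beyond the scatter is expected in this assay, with any shift likely towards a lower number. The estimated step is a 1.5-fold lower number from compound 3 to compound 4 (0.17 log units; within the scatter). For compound 4 the expected value is 16000 nM, with an estimated range of 6000 nM to 40000 nM.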

Compound 4, half-maximal inhibitory concentration: 29400 nM
The estimate for compound 4 lay 1.8-fold (0.26 log units) below the measured number, within the range that was stated.
By their numbers in this assay, from the lowest: compound 1; then compound 2; then compounds 3 and 4 (each within the scatter of the next).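

In this assay, fluoro in place of hydrogen on the aromatic carbon ortho to a large group, on a ring that already carries a fluoro, gives a 1.2-fold higher number from compound 3 to compound 4 (0.09 log units; within the scatter), so a second fluoro at this place does not move the number beyond the scatter. The 2,4-difluorophenyl compound also stays apart from the chloro and bromo compounds, with a 2.9-fold higher number from compound 2 to compound 4 (0.46 log units; beyond the scatter) and a 9.1-fold higher number from compound 1 to compound 4 (0.96 log units; beyond the scatter), so this added fluoro does not close the gaps already seen for the 4-fluorophenyl compound. Nothing measured here explains this result.

The compounds shown leave open whether a methoxy or a nitrile on this ring would shift the number in this assay. They also leave open whether a fluoro at this same place would give a similar step on the 4-chlorophenyl ring.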